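Para-halogen swap on the phenyl ring of compound 2

A few compounds are considered here, and "the series" means these few. Any claim that something is new, unique, unknown or untested is made for them only; others in the source may bear on it.

Measured so far:
compound 1, `c1ccc(-c2cn3ccnc3c(-c3ccc4ncn(C5CCCCC5)c4c3)n2)cc1`, 37.8%
compound 2, `Fc1ccc(-c2cn3ccnc3c(-c3ccc4ncn(C5CCCCC5)c4c3)n2)cc1`, 6.12%

In a functional assay on NCI-H460 cells (Homo sapiens) for inhibition, read by sulforhodamine B assay, with a stated time of 48 h, tested at 10 uM (a higher number here means more inhibition at the concentration tested (going by the name of the read-out), a lower number less inhibition), compound 2 stands lowest of the two values shown, and its nearest neighbour is compound 1, with a number 31.7 percentage points lower from compound 1 to compound 2 (beyond the scatter). Compound 3, `Clc1ccc(-c2cn3ccnc3c(-c3ccc4ncn(C5CCCCC5)c4c3)n2)cc1`, differs from compound 2 by chloro in place of fluoro on an aromatic carbon. For the measured compounds named here, the only measured step concerns fluoro in place of hydrogen, not chloro in place of fluoro, so no step bears directly on this change. A modest rise is expected, a number 8.9 percentage points higher from compound 2 to compound 3 (within the scatter), with wide uncertainty. Compound 3 is estimated at 15%, between 0% and 40%.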

Compound 3, a percentage reported as inhibition, at one concentration (the size of the read-out at that concentration, not a potency): 4.14%
Estimate against measurement, compound 3: 10.9 percentage points above; the range from low to high includes it.
By their numbers in this assay, from the lowest: compounds 3 and 2 (each within the scatter of the next); then compound 1.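

With chloro in place of fluoro on the 4-fluorophenyl ring, at the carbon para to a large group, the two halogens cannot be told apart: a number 2 percentage points lower from compound 2 to compound 3 (within the scatter). The drop first seen with fluoro is therefore not confined to that one halogen, since chloro in place of hydrogen gives a number 33.7 percentage points lower from compound 1 to compound 3 (beyond the scatter), and compound 1, with hydrogen at this carbon, remains beyond the scatter of both halogen compounds. Nothing available here accounts for this shared drop.

Still open, as far as these compounds go, is how a methoxy group, an amine or a carboxylic acid at this carbon would read. From the compounds shown here alone, it is also open whether any replacement for hydrogen here could match compound 1.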